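This account rests on a few compounds, and the source may have more. Where it says the series, first, only, none or still open, it means among the compounds named here.

Measured in a functional assay on SGC-7901 cells (Homo sapiens) for antiproliferative activity, in the presence of a further agent that is not named here; a higher number here means a weaker inhibitor, a lower number a stronger inhibitor:
compound 1, `NCCCCN[C@@H]1CC[C@@H](c2ccc(Cl)c(Cl)c2)c2ccccc21`: 6280 nM
compound 2, `NCCCCN[C@@H]1CC[C@H](c2ccc(Cl)c(Cl)c2)c2ccccc21`: 6300 nM

In this assay, among the compounds with values here, compound 2 gives the higher of the two numbers, yet it lies within the scatter of compound 1; the single measured step, a 1.0-fold higher number from compound 1 to compound 2 (0.00 log units; within the scatter), rests on a difference of configuration alone (the fact that compounds 1 and 2 differ only in the configuration as drawn). Compound 3, `NCCCCCCN[C@@H]1CC[C@H](c2ccc(Cl)c(Cl)c2)c2ccccc21`, differs from compound 2 by 2-aminoethyl in place of amino on a saturated chain carbon, four bonds along the chain from an amine nitrogen. Within the data shown here, no measured step concerns a change of this kind, so nothing here points in either direction for this assay. Compound 3 is therefore expected close to compound 2, estimated at 6000 nM with a range of 2000 nM to 18000 nM. The expected step of a 1.1-fold lower number from compound 2 to compound 3 (0.02 log units; within the scatter) is taken to lie within the scatter.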

Compound 3, half-maximal inhibitory concentration: 18900 nM
Estimate against measurement, compound 3: 3.2-fold (0.50 log units) below; the whole stated range lies below it.
By their numbers in this assay, from the lowest: compounds 1 and 2 (each within the scatter of the next); then compound 3.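

In this assay this position is not indifferent to change: 2-aminoethyl in place of amino on a saturated chain carbon, four bonds along the chain from an amine nitrogen, gives a 3.0-fold higher number from compound 2 to compound 3 (0.48 log units; beyond the scatter) and so a weaker inhibitor. Within the data shown here, the earlier pair varied configuration only and said nothing about chain length, so this modest step, resting on one pair, is the first reading on it. Nothing available bears on the reason for this rise.

Open, going by these compounds, is whether aminomethyl at this place gives a number nearer compound 2 or compound 3, and whether 3-aminopropyl extends the rise.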